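Aryl to 1-phenylethyl on the piperazine nitrogen: compound 4

The source may hold more compounds than are shown below. What is called first, only, known or untested is meant among the compounds shown, and "the series" means these compounds.

Measured so far in an assay on CHO cells for displacement of a labelled ligand from adenosine receptor A1 (Homo sapiens), read by scintillation counting, with a stated time of 90 min, tested at 1 uM, in the presence of a further agent that is not named here; on this read-out higher numbers stand for more inhibition at the one concentration tested (going by the name of the read-out) and lower numbers for less inhibition:
compound 1, `CCCn1c(=O)[nH]c2nc(-c3ccc(S(=O)(=O)N4CCN(c5ccc(F)cc5)CC4)cc3)[nH]c2c1=O`, 14%
compound 2, `CCCn1c(=O)[nH]c2nc(-c3ccc(S(=O)(=O)N4CCN(c5ccccc5Br)CC4)cc3)[nH]c2c1=O`, 28%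
compound 3, `CCCn1c(=O)[nH]c2nc(-c3ccc(S(=O)(=O)N4CCN(c5cccc(F)c5)CC4)cc3)[nH]c2c1=O`, 34%

Compound 3 gives the highest of the three numbers in this assay. Its nearest neighbour is compound 2, and that gap, a number 6 percentage points higher from compound 2 to compound 3 (within the scatter), is within the scatter, so the two cannot be ranked against each other. Compound 1 lies furthest away; the step of a number 20 percentage points higher from compound 1 to compound 3 (beyond the scatter) is beyond the scatter, as is a number 14 percentage points higher from compound 1 to compound 2 (beyond the scatter).

Compound 4, `CCCn1c(=O)[nH]c2nc(-c3ccc(S(=O)(=O)N4CCN(C(C)c5ccccc5)CC4)cc3)[nH]c2c1=O`, is the next compound to be measured. Compared with compound 3 the change is 1-phenylethyl in place of 3-fluorophenyl on an amine nitrogen in a ring. Among the compounds with values here, every step measured so far swaps one substituted phenyl ring for another on that same ring nitrogen; none of them exchanges an aromatic ring for a 1-phenylethyl group, so no measured step bears directly on this change. The aryl-to-aryl swaps moved the read-out by modest amounts or stayed within the scatter. With nothing closer to go on, the step of a number 6 percentage points lower from compound 3 to compound 4 (within the scatter) is expected to stay within the scatter, in either direction. The estimate for compound 4 in this assay is therefore 28%, in a range from 8% to 50%.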

Compound 4, a percentage reported as inhibition, at one concentration (the size of the read-out at that concentration, not a potency): 42%
Beside the measured number, compound 4's estimate is 14 percentage points below it; the measured number falls inside the stated range.
By their numbers in this assay, from the lowest: compound 1; then compounds 2, 3 and 4 (each within the scatter of the next, the first and the last beyond it).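

In this assay, placing 1-phenylethyl in place of 3-fluorophenyl on the amine nitrogen in a ring gives a number 8 percentage points higher from compound 3 to compound 4 (within the scatter) and so the two compounds cannot be ranked; this position therefore accepts a group other than a substituted phenyl with no readable loss of inhibition at the one concentration tested. Against the other two phenyl groups the result is clearer, with a number 14 percentage points higher from compound 2 to compound 4 (beyond the scatter) and a number 28 percentage points higher from compound 1 to compound 4 (beyond the scatter) on record for the same exchange, though both steps remain modest. No measurement shown here explains why these groups differ in this read-out.

The compounds shown leave open whether the methyl branch of 1-phenylethyl matters at all, a question that an unbranched benzyl group or the longer 2-phenylethyl chain on the same nitrogen would address. They also leave open whether an aromatic ring is needed at this position, which a cyclohexyl ring or a simple ethyl chain would test, and whether the two mirror-image forms of 1-phenylethyl behave alike.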